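The source may report more compounds than this note shows. Statements on the series, on what has been measured and on what is new or still open speak of the compounds shown alone.

Compound 1, `CCc1cc(C)cc2nc(N3CCN(C)CC3)oc12`: 0.26
Compound 2, `CN1CCN(c2nc3cccc(Cl)c3o2)CC1`: 0.24

Both compounds were tested in an assay on ileum (strain Hartley) with 5-hydroxytryptamine receptor 3A (Cavia porcellus) as the target; a higher number here means a larger maximal response, a lower number a smaller maximal response. Compound 2 stands lowest of the two measured numbers, but its nearest neighbour, compound 1, lies only within the usual scatter of it, so the two cannot be told apart on these numbers alone. Both share a core built from a fused two-ring system carrying a methylpiperazine, and each carries a single small group on the carbon ring.

Compound 3, `CCc1cccc2nc(N3CCN(C)CC3)oc12`, is the next compound, not yet measured in this assay. It differs from compound 2 in one place: ethyl in place of chloro on an aromatic carbon. Within the data shown here, no measured pair shows this exchange by itself, so its effect cannot be read off directly. What the data do offer is compound 1, which also carries an ethyl group, together with an added methyl, and which gives a value within the scatter of compound 2. On that basis the step from compound 2 to compound 3 is expected to be a number 0.010 higher from compound 2 to compound 3 (within the scatter), that is, nothing beyond the scatter in either direction. Compound 3 is therefore estimated to give about 0.25, with a likely range from 0.15 to 0.37.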

Compound 3, intrinsic activity: the largest response reached, as a fraction of the reference agonist's: 0.15
Estimate against measurement, compound 3: 0.10 above; the range from low to high includes it.
By their numbers in this assay, from the lowest: compounds 3, 2 and 1 (each within the scatter of the next, the first and the last beyond it).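

Hydrogen in place of methyl on an aromatic carbon gives a number 0.11 lower from compound 1 to compound 3 (beyond the scatter) in this assay and is the only step here that clears the scatter. Ethyl in place of chloro on the aromatic carbon ortho to a fused ring gives a number 0.090 lower from compound 2 to compound 3 (within the scatter) and so does not separate the two groups at this position in this assay. In these single changes, then, the maximal response shifts measurably with the methyl group, while the exchange of chloro for ethyl cannot be told from repeat-measurement noise, though three compounds are too few to call this a pattern.

Nothing measured here explains why either step comes out as it does. Still open, from the compounds shown here alone, is whether a different group at the ethyl position, such as a methoxy group, an amine or a longer chain, would move the response beyond the scatter, and whether adding the methyl group would produce a similar step if chloro stood in place of the ethyl.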